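The source may report more compounds than this note shows. Statements on the series, on what has been measured and on what is new or still open speak of the compounds shown alone.

Measured so far:
Compound 1 `O=C1c2ccccc2CN1c1cnc(NCc2c(F)ccc3c2CCO3)n2cnnc12` gives 13 mL.min-1.g-1 in an ADME assay on microsomes from liver (Homo sapiens) for metabolic stability, read by LC-MS, using NADPH, with stated times of 5 min and 30 min, tested at 1 uM; on this read-out lower numbers stand for slow clearance and higher numbers for fast clearance.
Compound 2 `Cc1nc(CN(C)C)ccc1-c1cnc(NCc2c(F)ccc3c2CCO3)c2cn[nH]c(=O)c12` gives 13 mL.min-1.g-1 in this assay.

On these numbers compound 1 stands level with compound 2, the two values sitting within the scatter of each other. The unmeasured compound 3 `CN(c1ncco1)c1cnc(NCc2c(F)ccc3c2CCO3)n2cnnc12` keeps the shared core of compound 1 but carries a different group on an aromatic carbon: a group of 7 heavy atoms (4 carbon, 2 nitrogen, 1 oxygen; one five-membered aromatic ring with 2 hetero atoms) in place of a group of 10 heavy atoms (8 carbon, 1 nitrogen, 1 oxygen; one five-membered non-aromatic ring with 1 hetero atom, one six-membered aromatic ring of carbon only), on an aromatic carbon. Going by the values given here, no measured pair shows what such a change does in this assay, so the expectation rests on compound 1 alone. The step from compound 1 to compound 3 is expected to be small and within the scatter, with a 1.3-fold lower number from compound 1 to compound 3 (0.11 log units; within the scatter). Compound 3 is thus estimated at 10 mL.min-1.g-1, in the range 4 mL.min-1.g-1 to 25 mL.min-1.g-1.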

Compound 3, intrinsic clearance in microsomes: 11 mL.min-1.g-1
For compound 3 the middle estimate is 1.1-fold (0.04 log units) below the measured one; measured number inside the range.
By their numbers in this assay, from the lowest: compounds 3, 1 and 2 (each within the scatter of the next).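

In this assay, replacing the two-ring group of compound 1 on this aromatic carbon with the smaller methyl(1,3-oxazol-2-yl)amino gives a 1.2-fold lower number from compound 1 to compound 3 (0.07 log units; within the scatter). This first pair at this position therefore shows that the read-out can stay within the scatter when a quite different group is attached here. No measurement at hand gives a reason for this. On these data alone, it remains open whether a plain amine or a short alkyl chain at this position would also leave the clearance unmoved. This single pair also cannot show whether the methyl or the oxazole ring of the new group matters.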